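The compounds below may be only part of what the source reports. "The series", "measured", "known", "first", "only" and "open" are said of these compounds alone.

Working notes on the series. The shared core carries a variable group on a saturated chain carbon bound to an aromatic nitrogen. Compound 1 `Cn1c(N)c(-c2nc3ccccc3[nH]2)c2nc(C#N)c(C#N)nc21` is measured in a functional assay on cells (Homo sapiens) for antiproliferative activity, read by MTT assay, with a stated time of 48 h; a lower number here means a stronger inhibitor, a higher number a weaker inhibitor. In this assay compound 1 reports only the limit > 50000 nM, not a number. Compound 3 `CCCCn1c(N)c(-c2nc3ccccc3[nH]2)c2nc(C#N)c(C#N)nc21` likewise reports only the limit > 50000 nM in this assay. Among the measured compounds shown here, compound 2 `CCN(CC)CCn1c(N)c(-c2nc3ccccc3[nH]2)c2nc(C#N)c(C#N)nc21` gives 25400 nM in this assay, the only finished number among the three. The step of an at least 1.9-fold lower number from compound 1 to compound 2 (0.29 log units; that floor lies within the scatter) is read against a limit, as is an at least 1.9-fold higher number from compound 2 to compound 3 (0.29 log units; that floor lies within the scatter); both rest on (the limit of > 50000 nM in this assay, at which 2 of the 3 values shown sit). The step that the two limits leave unreadable from compound 1 to compound 3 cannot be read from its two limits.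

Compound 4 `N#Cc1nc2c(-c3nc4ccccc4[nH]3)c(N)n(CCCN3CCCCC3)c2nc1C#N` is not yet measured in this assay. Its difference from compound 2 is (piperidin-1-yl)methyl in place of diethylamino on a saturated chain carbon, two bonds along the chain from an aromatic nitrogen. The bearing steps are those into and out of compound 2, each only a floor that lies within the scatter, so no direction can be drawn from them. Compound 4 keeps a chain amine as compound 2 does, and a step of a 1.4-fold lower number from compound 2 to compound 4 (0.15 log units; within the scatter) is expected, within the scatter. Compound 4 is therefore estimated at 18000 nM, with a range from 6000 nM to 50000 nM.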

Compound 4, half-maximal inhibitory concentration: 6230 nM
Compound 4: middle estimate off by 2.9-fold (0.46 log units), on the high side; the range from low to high includes it.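

At this position the series now has a step between two finished numbers in this assay: a 4.1-fold lower number from compound 2 to compound 4 (0.61 log units; beyond the scatter). Where the steps around compound 2 could not be told from the scatter, the steps to compound 4 now clear it, with an at least 8.0-fold lower number from compound 3 to compound 4 (0.90 log units; beyond the scatter) and an at least 8.0-fold lower number from compound 1 to compound 4 (0.90 log units; beyond the scatter), so a chain ending in an amine is separated from the butyl and methyl groups by more than the scatter for the first time, and the choice of chain amine also changes the number. The last two steps are floors, read against a limit and not against a number: the limit of > 50000 nM in this assay, at which 2 of the 4 values shown sit.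

The change from 2-(diethylamino)ethyl to 3-(piperidin-1-yl)propyl alters the ring and the chain length together, so the compounds shown do not divide the step between the two; 2-(piperidin-1-yl)ethyl and 3-(diethylamino)propyl would each separate one from the other. Also open, from the compounds shown here alone, is how far the trend carries, for example to a morpholin-4-yl group on the same propyl chain, or to a butyl chain ending in piperidin-1-yl.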